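Difluorophenyl for dimethoxyphenyl on the ketone carbon

The source may hold more compounds than are shown below. What is called first, only, known or untested is meant among the compounds shown, and "the series" means these compounds.

In a functional assay on KM12 cells (Homo sapiens) for cytotoxicity, read by sulforhodamine B assay, with a stated time of 48 h, tested at 1 uM (on this read-out higher numbers stand for a weaker effect at the one concentration tested and lower numbers for a stronger effect), compound 1 `COc1cc(-c2cc(/C=C/C(=O)c3ccc(Cl)c(Cl)c3)[nH]n2)cc(OC)c1OC` gives 85%. Compound 2 `COc1ccc(C(=O)/C=C/c2cc(-c3cc(OC)c(OC)c(OC)c3)n[nH]2)cc1` gives 83%, and a number 2 percentage points lower from compound 1 to compound 2 (within the scatter). Compound 3 `COc1ccc(C(=O)/C=C/c2cc(-c3cc(OC)c(OC)c(OC)c3)n[nH]2)cc1OC` gives 54%, the lowest of the three numbers, which here means the strongest effect at the single concentration. The two steps into it are large: a number 31 percentage points lower from compound 1 to compound 3 (beyond the scatter) and a number 29 percentage points lower from compound 2 to compound 3 (beyond the scatter).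

Compound 4 `COc1cc(-c2cc(/C=C/C(=O)c3ccc(F)c(F)c3)[nH]n2)cc(OC)c1OC` differs from compound 3 by 3,4-difluorophenyl in place of 3,4-dimethoxyphenyl on a carbonyl carbon. This undoes the dimethoxy pair and places a pair of halogens on the carbonyl-bound ring, as in compound 1, so the bearing steps are the two just given. The change from compound 3 to compound 4 is therefore expected to run upward by a comparable amount, a number 24 percentage points higher from compound 3 to compound 4 (beyond the scatter). Compound 4 is estimated at 78%, within 60% to 95%.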

Compound 4, a percentage reported as activity, at one concentration (the size of the read-out at that concentration, not a potency): 95%
Estimate against measurement, compound 4: 17 percentage points below; the measured number falls inside the stated range.
By their numbers in this assay, from the lowest: compound 3; then compounds 2, 1 and 4 (each within the scatter of the next, the first and the last beyond it).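

At the carbonyl carbon, 3,4-difluorophenyl does not keep the stronger effect seen with 3,4-dimethoxyphenyl in this assay (a number 41 percentage points higher from compound 3 to compound 4 (beyond the scatter)). It also separates from 4-methoxyphenyl (a number 12 percentage points higher from compound 2 to compound 4 (beyond the scatter)), while 3,4-difluorophenyl and 3,4-dichlorophenyl are not told apart (a number 10 percentage points higher from compound 1 to compound 4 (within the scatter)). Of the four groups on this carbon, only 3,4-dimethoxyphenyl lies beyond the scatter from all three others. No measurement at hand accounts for this difference.

Open: whether a hydroxyl or an amine on this ring can replace a methoxy and keep the effect. From the compounds shown here alone, the effect at other concentrations is also open.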